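The compounds below may be only part of what the source reports. "The series", "measured", "known", "first", "only" and "open" are said of these compounds alone.

In a functional assay on HEK293 cells for agonist activity at Free fatty acid receptor 1 (Homo sapiens), read by fluorescence and calcium flux, with a stated time of 10 min (on this read-out higher numbers stand for an effect only at larger amounts of compound and lower numbers for an effect already at smaller amounts), compound 1 `CC#C[C@@H](CC(=O)O)c1ccc(OC[C@H]2COc3cc(Cl)ccc3O2)cc1` gives 110 nM. Compound 2 `CC#C[C@@H](CC(=O)O)c1ccc(OC[C@H]2COc3cc(F)c(Cl)cc3O2)cc1` gives 210 nM in this assay; the gap between these two numbers lies within the scatter, so neither compound can be set above the other. Compound 3 `CC#C[C@@H](CC(=O)O)c1ccc(OC[C@H]2COc3cc(Cl)c(Cl)cc3O2)cc1` differs from compound 2 by chloro in place of fluoro on an aromatic carbon. Among the measured compounds shown here, no step between measured compounds shows what such an exchange does here. Replacing fluoro with chloro is expected to shift the number little, if at all beyond the scatter, and the expected step from compound 2 to compound 3 is a 1.0-fold higher number from compound 2 to compound 3 (0.02 log units; within the scatter). Compound 3 is therefore estimated at 220 nM, within a range from 90 nM to 550 nM.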

Compound 3, half-maximal effective concentration: 150 nM
Estimate against measurement, compound 3: 1.5-fold (0.17 log units) above; low and high end bracket the measured number.
By their numbers in this assay, from the lowest: compounds 1, 3 and 2 (each within the scatter of the next).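

On this aromatic carbon, chloro in place of fluoro gives a 1.4-fold lower number from compound 2 to compound 3 (0.15 log units; within the scatter), and chloro in place of hydrogen gives a 1.4-fold higher number from compound 1 to compound 3 (0.13 log units; within the scatter). Neither exchange therefore moves the number beyond the scatter, so hydrogen, fluoro and chloro cannot be ranked by these steps. Nothing available explains these results. The compounds shown leave open whether a larger group or a different kind of group here, such as methoxy, trifluoromethyl or an amine, would shift the number beyond the scatter, and in which direction.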